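This account rests on a few compounds, and the source may have more. Where it says the series, first, only, none or still open, it means among the compounds named here.

Working notes on the series, read in a functional assay on MCF7 cells (Homo sapiens) for antiproliferative activity, read by MTT assay, with a stated time of 48 h; on this read-out lower numbers stand for stronger inhibition and higher numbers for weaker inhibition. Compound 1 (`COc1ccc2c(/C=C/C(=O)c3cc(OC)c(OC)c(SC)c3)c[nH]c2c1`) gives 101 nM, the middle of three numbers. Compound 3 (`COc1ccc2c(/C=C(\C)C(=O)c3cc(OC)c(OC)c([Se]C)c3)cn(C)c2c1`) gives a lower 44 nM and compound 2 (`COc1ccc2c(/C=C/C(=O)c3cc(N)c(OC)c(OC)c3)cn(C)c2c1`) a higher 505 nM, both gaps beyond the scatter. Compound 4 (`COc1ccc2c(/C=C/C(=O)c3cc(OC)c(OC)c([N+](=O)[O-])c3)c[nH]c2c1`) carries nitro in place of methylsulfanyl on an aromatic carbon. Among the measured compounds shown here, no measured pair isolates this change, and no measured compound holds a nitro group. The expectation leans weakly on compound 2, which has no methylsulfanyl and differs elsewhere too, at 505 nM. A moderate move towards weaker inhibition is expected, estimated as a 3.0-fold higher number from compound 1 to compound 4 (0.47 log units; beyond the scatter). The estimate for compound 4 is 300 nM, with an expected range from 80 nM to 1200 nM.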

Compound 4, half-maximal inhibitory concentration: 662 nM
For compound 4 the middle estimate is 2.2-fold (0.34 log units) below the measured one; the measured number falls inside the stated range.
By their numbers in this assay, from the lowest: compound 3; then compound 1; then compounds 2 and 4 (each within the scatter of the next).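

At this position, on an aromatic carbon ortho to a methoxy group, nitro in place of methylsulfanyl gives a 6.6-fold higher number from compound 1 to compound 4 (0.82 log units; beyond the scatter) in this assay. With the core of compound 1 otherwise unchanged, the methylsulfanyl group is therefore not interchangeable with nitro in this read-out. Nothing available explains the size of this step. As far as these compounds go, only this one replacement can be read at the position, so the effect of a hydroxyl group or an ethylsulfanyl chain there remains open. From the compounds shown here alone, whether the step would keep its size on the cores of compound 2 and compound 3 also remains open.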